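A Tolyl Sulfonyl Group on the Amine of Compound 1

A few compounds are considered here, and "the series" means these few. Any claim that something is new, unique, unknown or untested is made for them only; others in the source may bear on it.

compound 1 `N#CC1=C(N)Oc2nc(Nc3ccc(S(N)(=O)=O)cc3)sc2C1c1ccc(Cl)cc1` — 39400 nM
compound 2 `N#CC1=C(NS(=O)(=O)c2ccccc2)Oc2nc(Nc3ccc(S(N)(=O)=O)cc3)sc2C1c1ccc(Cl)cc1` — 47500 nM

Within the data shown here, in a functional assay on MCF7 cells (Homo sapiens) for antiproliferative activity, read by sulforhodamine B assay, with a stated time of 48 h (a higher number here means a weaker inhibitor, a lower number a stronger inhibitor), compound 1 gives 39400 nM, the lower of the two numbers measured so far; its only neighbour is compound 2, which gives 47500 nM. Among the measured compounds shown here, the single step between them, a 1.2-fold higher number from compound 1 to compound 2 (0.08 log units; within the scatter), is where a phenylsulfonyl group entered on the same amine nitrogen, and the number did not move beyond the scatter. Compound 3 `Cc1ccc(S(=O)(=O)NC2=C(C#N)C(c3ccc(Cl)cc3)c3sc(Nc4ccc(S(N)(=O)=O)cc4)nc3O2)cc1` differs from compound 1 by (4-methylphenyl)sulfonyl in place of hydrogen on an amine nitrogen. For the measured compounds named here, the (4-methylphenyl)sulfonyl group differs from the phenylsulfonyl of compound 2 only by its methyl, so the step from compound 1 to compound 2 is the one measurement that bears on this change. Compound 3 is therefore expected to show a 1.1-fold higher number from compound 1 to compound 3 (0.06 log units; within the scatter), no shift beyond the scatter. The estimate for compound 3 in this assay is 45000 nM, expected to fall between 20000 nM and 100000 nM.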

Compound 3, half-maximal inhibitory concentration: 71700 nM
Estimate against measurement, compound 3: 1.6-fold (0.20 log units) below; low and high end bracket the measured number.
By their numbers in this assay, from the lowest: compounds 1, 2 and 3 (each within the scatter of the next).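

In this assay this amine nitrogen now carries two different sulfonyl groups, and neither moves the number beyond the scatter: the (4-methylphenyl)sulfonyl group gives a 1.8-fold higher number from compound 1 to compound 3 (0.26 log units; within the scatter) and so leaves compound 3 level with compound 1. The methyl itself, in place of hydrogen on an aromatic carbon of the phenylsulfonyl group, gives a 1.5-fold higher number from compound 2 to compound 3 (0.18 log units; within the scatter) and so adds no change that can be told from the scatter either. No measurement shown here offers an explanation for these numbers.

The compounds shown leave open whether a sulfonyl group without an aromatic ring, such as methylsulfonyl, or an acetyl group on this nitrogen would behave the same way. They also leave open whether a methoxy group or a chlorine atom in place of the methyl would shift the number beyond the scatter.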